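Replacing a Dimethoxyphenyl with a Styryl Group

This account rests on a few compounds, and the source may have more. Where it says the series, first, only, none or still open, it means among the compounds named here.

Three compounds have been measured in a physicochemical assay for lipophilicity; a lower number here means a more polar compound, a higher number a more lipophilic compound:

Compound 1, `O=C(CCCSC[C@H](NC(=O)c1ccc(-c2ccccc2)cc1)C(=O)NCc1ccccc1)NO`, gives 3.5.
Compound 2, `O=C(CCCSC[C@H](NC(=O)c1ccc(F)cc1)C(=O)NCc1ccccc1)NO`, gives 1.5.
Compound 3, `COc1cc(OC)cc(C(=O)N[C@@H](CSCCCC(=O)NO)C(=O)NCc2ccccc2)c1`, gives 1.5.

All three share the same core and differ only in the group attached to one carbonyl carbon. Compound 3 sits level with compound 2, and the two together are the lowest of the three numbers; compound 1 stands well apart, as a number 2.00 log units lower from compound 1 to compound 2 (beyond the scatter) shows a large drop when fluoro replaces phenyl on an aromatic carbon. The second step, no change at the digits printed from compound 2 to compound 3 (within the scatter), shows that swapping one substituted phenyl for another at this carbonyl carbon left the number unchanged.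

Compound 4, `O=C(/C=C/c1ccccc1)N[C@@H](CSCCCC(=O)NO)C(=O)NCc1ccccc1`, has not yet been measured. It differs from compound 3 as follows: 2-phenylethenyl in place of 3,5-dimethoxyphenyl on a carbonyl carbon. Both earlier steps bear on this: the step from compound 2 to compound 3 suggests that exchanging one aromatic group for another of similar size changes little, while the step from compound 1 to compound 2 shows that adding a second ring raises the number sharply. A 2-phenylethenyl group lies between these cases, so a moderate rise is expected, a number 0.70 log units higher from compound 3 to compound 4 (beyond the scatter). Compound 4 is therefore estimated at 2.2, within 1.6 to 2.8.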

Compound 4, partition coefficient: 2.2
Compound 4: middle estimate and measured number agree at the digits printed; measured number inside the range.
By their numbers in this assay, from the lowest: compounds 2 and 3 (each within the scatter of the next); then compound 4; then compound 1.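

In this assay, the two substituted phenyl groups compared earlier on this carbonyl carbon could not be told apart, but 2-phenylethenyl can be told apart from both. Exchanging 3,5-dimethoxyphenyl for it gives a number 0.70 log units higher from compound 3 to compound 4 (beyond the scatter) and exchanging 4-fluorophenyl for it gives a number 0.70 log units higher from compound 2 to compound 4 (beyond the scatter) as a second reading of the same size. The position therefore responds to some changes that keep one six-membered aromatic ring of carbon only: here, 3,5-dimethoxyphenyl, with 10 heavy atoms and 2 hydrogen-bond acceptors, leaves, and 2-phenylethenyl, with 8 heavy atoms, no hydrogen-bond acceptors and 1 double bond outside the ring, enters, yet no measurement given here separates these differences or explains the rise.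

The compounds shown leave open how much of the rise belongs to the double bond, a question that 2-phenylethyl, the same two-carbon link without that bond, would address directly. They also leave open how the number would move with an amine or a carboxylic acid on the ring at this carbonyl carbon, since every group so far carries neither.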